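1H-Indol-2-yl in Place of Phenyl on Compound 1

The source may report more compounds than this note shows. Statements on the series, on what has been measured and on what is new or still open speak of the compounds shown alone.

Compound 1 `CCN1CCN(c2cc(C)c3cc(NC(=O)c4ccccc4)ccc3n2)CC1` in a functional assay on SK-BR-3 cells (Homo sapiens) for antiproliferative activity, read by MTT assay, with a stated time of 72 h (a lower number here means a stronger inhibitor, a higher number a weaker inhibitor), gives 18400 nM. Among the three numbers measured it stands second highest: compound 2 `Cc1cc(NCCN2CCCC2)nc2ccc(NC(=O)c3ccc(Cl)c(Cl)c3)cc12` gives 9530 nM, a gap to compound 1 within the scatter, while compound 3 `Cc1cc(N2CCCCC2)nc2ccc(NC(=O)c3ccc(Cl)c(Cl)c3)cc12` gives 42500 nM, a gap beyond it. For the measured compounds named here, the only step between two measured compounds is a 4.5-fold higher number from compound 2 to compound 3 (0.65 log units; beyond the scatter), and it alters the amine end of the shared core, not the group on the carbonyl carbon. Compound 4 `CCN1CCN(c2cc(C)c3cc(NC(=O)c4cc5ccccc5[nH]4)ccc3n2)CC1` differs from compound 1 by 1H-indol-2-yl in place of phenyl on a carbonyl carbon. Going by the values given here, no measured step bears on this change, so the expectation is a step of a 1.3-fold lower number from compound 1 to compound 4 (0.12 log units; within the scatter), none beyond the scatter. Compound 4 is therefore estimated at 14000 nM, with a range from 4000 nM to 45000 nM.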

Compound 4, half-maximal inhibitory concentration: 2550 nM
Compound 4: the middle estimate sits 5.5-fold (0.74 log units) above what was measured; the measured number lies below the stated range.
By their numbers in this assay, from the lowest: compound 4; then compounds 2 and 1 (each within the scatter of the next); then compound 3.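

In this assay, the group on the carbonyl carbon moves the number on its own: 1H-indol-2-yl in place of phenyl gives a 7.2-fold lower number from compound 1 to compound 4 (0.86 log units; beyond the scatter). For the compounds shown here, the only earlier step changed the amine end of the shared core, so this is the first measured effect at this position. The change adds a second ring and a hydrogen-bond donor together, and no measurement at hand accounts for the step.

A benzofuran-2-yl or 1H-pyrrol-2-yl group on the same carbonyl carbon would help separate those two additions. On these data alone, whether the step holds with piperidin-1-yl at the amine end also remains open.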